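This account rests on a few compounds, and the source may have more. Where it says the series, first, only, none or still open, it means among the compounds named here.

Compound 1, whose structure is `CC(=O)O[C@@H]1OC(=O)[C@@](C)(C(C)=O)[C@@H]1C`, is the reference point of this small set. In a functional assay on HT-29 cells (Homo sapiens) for cytotoxicity, read by MTT assay (a lower number here means a stronger inhibitor, a higher number a weaker inhibitor), compound 1 gives 12000 nM, the lowest of the two numbers that were obtained. Compound 2, with the structure `CC(=O)O[C@@H]1OC(=O)[C@@](Cc2ccccc2)(C(C)=O)[C@@H]1C`, gives in this assay a value of 39000 nM, and the step from compound 1 is a 3.3-fold higher number from compound 1 to compound 2 (0.51 log units; beyond the scatter). Compound 3, built as `CC(=O)O[C@@H]1OC(=O)[C@@](OC(C)=O)(C(C)=O)[C@@H]1C`, reaches only a limit of the assay: in this assay compound 3 is recorded as > 50000 nM. Against compound 1 that is an at least 4.1-fold higher number from compound 1 to compound 3 (0.61 log units; beyond the scatter), and the comparison with compound 2 is an at least 1.2-fold higher number from compound 2 to compound 3 (0.10 log units; that floor lies within the scatter), which cannot be separated from the scatter. Compound 4, with the structure `CC(=O)O[C@@H]1OC(=O)[C@@](C)(C(=O)c2ccccc2)[C@@H]1C`, is not yet measured. It differs from compound 1 by phenyl in place of methyl on a carbonyl carbon. Among the measured compounds shown here, no measured step repeats this exact change; the nearest guides are the phenyl that enters in compound 2 and the acetoxy that enters in compound 3, both of which raised the number by a modest amount. By analogy a modest rise is expected for compound 4 as well, so that in this assay compound 4 is estimated at 25000 nM, within a range from 8000 nM to 60000 nM. That estimate means a step of a 2.1-fold higher number from compound 1 to compound 4 (0.32 log units; beyond the scatter).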

Compound 4, half-maximal inhibitory concentration: 7000 nM
For compound 4 the middle estimate is 3.6-fold (0.55 log units) above the measured one; the measured number lies below the stated range.
By their numbers in this assay, from the lowest: compounds 4 and 1 (each within the scatter of the next); then compound 2. At a limit, above all of these: compound 3.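

In this assay, phenyl in place of methyl on a carbonyl carbon gives a 1.7-fold lower number from compound 1 to compound 4 (0.23 log units; within the scatter), so compound 4 and compound 1 cannot be told apart, even though the new group brings a six-membered aromatic ring to this position. Among the compounds shown here, the only phenyl among the earlier compounds sits on a saturated chain carbon bound to a saturated ring carbon, where the step was a 3.3-fold higher number from compound 1 to compound 2 (0.51 log units; beyond the scatter), and a rise of that kind does not appear at the carbonyl carbon. The compounds shown offer no measurement that accounts for this result.

Going by these compounds, it remains open whether another group on this carbonyl carbon, such as an amine, a carboxylic acid or a longer chain, would move the number beyond the scatter in either direction. Also open, on these data alone, is how a phenyl bearing a methoxy group or a chlorine would read in this assay, and whether phenyl on the carbonyl carbon would give the same picture with the benzyl group of compound 2 on the saturated ring carbon.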